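Trimethoxyphenyl in Place of Phenyl on Compound 2

The compounds below may be only part of what the source reports. "The series", "measured", "known", "first", "only" and "open" are said of these compounds alone.

Compound 2 `COc1cc(/C=C/C(=O)c2cccc(-n3cc(-c4ccccc4)[nH]c3=O)c2)cc(OC)c1OC` gives 4030 nM in a functional assay on A549 cells (Homo sapiens) for inhibition; a higher number here means a weaker inhibitor of growth, a lower number a stronger inhibitor of growth. It stands second highest of the three numbers, with compound 3 `COc1ccc(-c2cn(-c3cccc(C(=O)/C=C/c4ccc(O)c(OC)c4)c3)c(=O)[nH]2)cc1` at 4140 nM and compound 1 `COc1cc(/C=C/C(=O)c2cccc(-n3cc(-c4ccccc4)[nH]c3=O)c2)ccc1O` at 3850 nM, both within the scatter of it. Compound 4 `COc1cc(/C=C/C(=O)c2cccc(-n3cc(-c4cc(OC)c(OC)c(OC)c4)[nH]c3=O)c2)cc(OC)c1OC` differs from compound 2 by 3,4,5-trimethoxyphenyl in place of phenyl on an aromatic carbon. Going by the values given here, the only measured step touching that phenyl, a 1.1-fold higher number from compound 1 to compound 3 (0.03 log units; within the scatter), put a single methoxy there and stayed within the scatter; no measured step adds three methoxy groups at once. In this assay the step is therefore expected to remain within the scatter, a 1.0-fold lower number from compound 2 to compound 4 (0.00 log units; within the scatter). Compound 4 is estimated at 4000 nM, with a range from 1500 nM to 11000 nM.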

Compound 4, concentration for 50% growth inhibition: 3030 nM
For compound 4 the middle estimate is 1.3-fold (0.12 log units) above the measured one; the measured number falls inside the stated range.
By their numbers in this assay, from the lowest: compounds 4, 1, 2 and 3 (each within the scatter of the next).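

In this assay, going by these compounds alone, the aromatic carbon of the five-membered ring accepts the whole 3,4,5-trimethoxyphenyl in place of phenyl, with a 1.3-fold lower number from compound 2 to compound 4 (0.12 log units; within the scatter), so the tolerance there extends beyond the single methoxy of the earlier compounds. A far larger group at this position therefore leaves the number within the scatter, in this one pair. Nothing available explains this result.

The compounds shown leave open whether a group of another kind at this position, such as an amine or a carboxylic acid on the phenyl, would also stay within the scatter.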